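Solubility along the acid, amide and ether variants

The source may report more compounds than this note shows. Statements on the series, on what has been measured and on what is new or still open speak of the compounds shown alone.

Compound 1 `Cc1cc(C(=O)O)ccc1-c1c(N)c(C(=O)c2ccc(F)cc2F)cc[n+]1[O-]`: in a physicochemical assay for solubility, at pH 9.0 (on this read-out lower numbers stand for lower solubility and higher numbers for higher solubility), compound 1 gives > 1000 ug/mL, which is a limit of the assay and not a number.
Compound 2 `COCCNC(=O)c1ccc(-c2c(N)c(C(=O)c3ccc(F)cc3F)cc[n+]2[O-])c(C)c1`: in this assay compound 2 gives 49 ug/mL.

Among the measured compounds shown here, compound 2 holds the only numeric value in this assay; the one other value is a limit, namely (the limit of > 1000 ug/mL in this assay, at which 1 of the 2 values shown sits). For the measured compounds named here, the single measured step, an at least 20-fold lower number from compound 1 to compound 2 (1.30 log units; beyond the scatter), concerns (2-methoxyethyl)amino in place of hydroxy on a carbonyl carbon.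

Compound 3 `COCCOc1ccc(-c2c(N)c(C(=O)c3ccc(F)cc3F)cc[n+]2[O-])c(C)c1` differs from compound 2 by 2-methoxyethoxy in place of (2-methoxyethyl)carbamoyl on an aromatic carbon. The 2-methoxyethyl chain is kept; the carbonyl and the amide hydrogen go. Going by the values given here, no measured step covers a change of this kind, and the step from compound 1 to compound 2 is of another kind, so it gives no direct guide to size or direction. In the absence of a comparable step, the expected change in this assay from compound 2 to compound 3 is a 1.4-fold lower number from compound 2 to compound 3 (0.15 log units; within the scatter), that is, nothing beyond the scatter. Compound 3 is therefore estimated at 35 ug/mL, with a range from 10 ug/mL to 150 ug/mL.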

Compound 3, solubility: 89 ug/mL
Compound 3: the middle estimate sits 2.5-fold (0.41 log units) below what was measured; the range from low to high includes it.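

In this assay, the swap of the amide link for the ether link at this position, on an aromatic carbon para to a large group, gives a 1.8-fold higher number from compound 2 to compound 3 (0.26 log units; within the scatter); with the 2-methoxyethyl chain kept, loss of the carbonyl and the amide hydrogen therefore moves the read-out by no more than the usual scatter. Replacing carboxy with 2-methoxyethoxy gives an at least 11-fold lower number from compound 1 to compound 3 (1.05 log units; beyond the scatter), which puts compound 3 on the same side of compound 1 as compound 2, so the large gap now appears with two different replacements of carboxy and not with the amide alone. Compound 1 sits at a limit of the assay and not at a number, so neither large step has a measured upper size: the limit of > 1000 ug/mL in this assay, at which 1 of the 3 values shown sits.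

Still open, going by these compounds, is whether a 2-methoxyethyl chain carrying a terminal amine, or a longer ether chain, at this position would stay level with compound 2 and compound 3 or move toward compound 1. On these data alone, the true distance of compound 1 from the two neutral side chains also remains open, as does the behaviour of all three compounds in this read-out at a pH other than the one used here.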